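Trading one side chain of compound 1 for hydrogen

The compounds below may be only part of what the source reports. "The series", "measured", "known", "first", "only" and "open" are said of these compounds alone.

Compound 1 `N[C@@H](CCC(=O)OC[C@H]1O[C@@H](n2cc(F)c(=O)[nH]c2=O)C[C@@H]1OC(=O)CC[C@H](N)C(=O)O)C(=O)O`: 3100000 nM
Compound 2 `N[C@@H](CCC(=O)O[C@H]1C[C@H](n2cc(F)c(=O)[nH]c2=O)O[C@@H]1CO)C(=O)O`: 1600000 nM

Both numbers come from a functional assay on ZR-75-1 cells (Homo sapiens) for inhibition, read by MTT assay, with a stated time of 24 h; on this read-out lower numbers stand for stronger inhibition of growth and higher numbers for weaker inhibition of growth. Compound 1 gives 3100000 nM, and only compound 2 is available for comparison, with the two values lying within the scatter of each other.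

The next compound to consider is compound 3 `N[C@@H](CCC(=O)OC[C@H]1O[C@@H](n2cc(F)c(=O)[nH]c2=O)C[C@@H]1O)C(=O)O`, which differs from compound 1 by one change: hydrogen in place of (3-amino-3-carboxypropyl)carbonyl on an oxygen on a saturated carbon. In words, this is hydrogen in place of (3-amino-3-carboxypropyl)carbonyl on an oxygen on a saturated carbon. For the measured compounds named here, compound 2 shows the same kind of swap on a different oxygen, and it is the only measured guide: a 1.9-fold lower number from compound 1 to compound 2 (0.29 log units; within the scatter). A similar small shift to a lower number is therefore expected in this assay, with nothing beyond the scatter. The estimated change is a 1.7-fold lower number from compound 1 to compound 3 (0.24 log units; within the scatter). For compound 3 the expected value is 1800000 nM, within an estimated range of 800000 nM to 3600000 nM.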

Compound 3, concentration for 50% growth inhibition: 1700000 nM
The estimate for compound 3 lay 1.1-fold (0.02 log units) above the measured number; low and high end bracket the measured number.
By their numbers in this assay, from the lowest: compounds 2, 3 and 1 (each within the scatter of the next).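

In this assay the swap to hydrogen on this oxygen, on a saturated carbon whose other neighbours are saturated ring carbon, gives a 1.8-fold lower number from compound 1 to compound 3 (0.26 log units; within the scatter) as its step. Compound 1 can thus lose this (3-amino-3-carboxypropyl)carbonyl group with the two numbers still inside the usual scatter, and the swap on the other oxygen reads the same way, with a 1.9-fold lower number from compound 1 to compound 2 (0.29 log units; within the scatter) as its step, so neither side chain on its own shows a measurable effect on growth inhibition here. Nothing available explains why these numbers stay so close.

Still open, on these data alone, is whether a different group on this oxygen, such as an acetyl ester or a longer carbon chain, would move the number beyond the scatter. As far as these compounds go, it is equally open whether an amine in place of this oxygen would do so, or whether removing both side chains together would.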